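The source may report more compounds than this note shows. Statements on the series, on what has been measured and on what is new or still open speak of the compounds shown alone.

In a functional assay on NCI-N87 cells (Homo sapiens) for antiproliferative activity, read by CCK-8 assay, with a stated time of 72 h (on this read-out higher numbers stand for weaker inhibition and lower numbers for stronger inhibition), three compounds sharing one core have been measured: compound 1 `Cc1cc(Nc2cc(N3CCN(C)CC3)nc(Nc3ccc(S(N)(=O)=O)cc3)n2)n[nH]1` gives 24000 nM, compound 2 `Cc1cc(Nc2cc(N3CCN(C)CC3)nc(Nc3ccc([N+](=O)[O-])cc3)n2)n[nH]1` gives 3880 nM, and compound 3 `Cc1cc(Nc2cc(N3CCN(C)CC3)nc(Nc3cccc(Cl)c3)n2)n[nH]1` gives 1770 nM, the lowest of the three numbers. Compound 4 `Cc1cc(Nc2cc(N3CCN(C)CC3)nc(Nc3ccc(C#N)cc3)n2)n[nH]1` carries 4-cyanophenyl in place of 3-chlorophenyl on a nitrogen on an aromatic ring. Within the data shown here, two measured steps bear on this change. Replacing 4-nitrophenyl with 3-chlorophenyl gave a 2.2-fold lower number from compound 2 to compound 3 (0.34 log units; beyond the scatter), a modest step, while replacing 4-sulfamoylphenyl with 3-chlorophenyl gave a 14-fold lower number from compound 1 to compound 3 (1.13 log units; beyond the scatter), a large one. Going back to a 4-substituted phenyl should therefore raise the number in this assay, and a modest rise is expected, closer to the step involving compound 2. The expected change is a 2.1-fold higher number from compound 3 to compound 4 (0.33 log units; beyond the scatter). For compound 4, the estimate is 3800 nM, with an expected range of 1300 nM to 11000 nM.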

Compound 4, half-maximal inhibitory concentration: 5780 nM
Beside the measured number, compound 4's estimate is 1.5-fold (0.18 log units) below it; measured number inside the range.
By their numbers in this assay, from the lowest: compound 3; then compounds 2 and 4 (each within the scatter of the next); then compound 1.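

Moving from 3-chlorophenyl to 4-cyanophenyl in this assay gives a 3.3-fold higher number from compound 3 to compound 4 (0.51 log units; beyond the scatter) and makes this the third 4-substituted phenyl group with a higher number than the 3-chlorophenyl of compound 3. Cyano for nitro gives a 1.5-fold higher number from compound 2 to compound 4 (0.17 log units; within the scatter) so these two groups cannot be told apart here, while cyano for sulfamoyl gives a 4.2-fold lower number from compound 1 to compound 4 (0.62 log units; beyond the scatter) and leaves sulfamoyl with the highest number. Nothing measured here explains these differences. Still open, as far as these compounds go, is whether the low number of compound 3 follows the chlorine or its place on the ring. A 4-chlorophenyl or 3-cyanophenyl group would separate the two.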